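From Hydroxy to Ethoxy on the Isopropyl Compound

A few compounds are considered here, and "the series" means these few. Any claim that something is new, unique, unknown or untested is made for them only; others in the source may bear on it.

Measured in a functional assay on BT-474 cells (Homo sapiens) for antiproliferative activity, read by sulforhodamine B assay, with a stated time of 4 days; a higher number here means a weaker inhibitor of growth, a lower number a stronger inhibitor of growth:
Compound 1 `COc1cc(Cl)c(-c2nc(SCC(=O)NC3CC3)nc3[nH]cc(C#N)c23)cc1O`: 102 nM
Compound 2 `CCOc1cc(-c2nc(SCC(=O)NC3CC3)nc3[nH]cc(C#N)c23)c(Cl)cc1OC`: 25 nM
Compound 3 `COc1cc(Cl)c(-c2nc(SCC(=O)NC(C)C)nc3[nH]cc(C#N)c23)cc1O`: 161 nM

Compound 3 stands close to compound 1: isopropyl in place of cyclopropyl on an amide-type nitrogen gives a 1.6-fold higher number from compound 1 to compound 3 (0.20 log units; within the scatter), so these two cannot be told apart. By contrast, compound 3 reads 161 nM, while compound 2 reads 25 nM, a clearly lower number.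

The next compound, compound 4 `CCOc1cc(-c2nc(SCC(=O)NC(C)C)nc3[nH]cc(C#N)c23)c(Cl)cc1OC`, keeps the isopropyl group and makes one change to compound 3: ethyl in place of hydrogen on an oxygen on an aromatic ring. Read one bond further out, this is hydroxy to ethoxy.

The same change has been measured only once, with cyclopropyl on the amide-type nitrogen, and it gave a 4.1-fold lower number from compound 1 to compound 2 (0.61 log units; beyond the scatter). Whether it carries over to the isopropyl compounds is not yet shown. Going by a 4.1-fold lower number from compound 1 to compound 2 (0.61 log units; beyond the scatter) and the small 1.6-fold higher number from compound 1 to compound 3 (0.20 log units; within the scatter), a step of similar size towards a lower number is expected in this assay. The expected step is a 4.0-fold lower number from compound 3 to compound 4 (0.60 log units; beyond the scatter). For compound 4 the estimate is 40 nM, with an expected range from 18 nM to 90 nM.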

Compound 4, concentration for 50% growth inhibition: 84 nM
Estimate against measurement, compound 4: 2.1-fold (0.32 log units) below; measured number inside the range.
By their numbers in this assay, from the lowest: compound 2; then compounds 4, 1 and 3 (each within the scatter of the next).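

In this assay, hydroxy to ethoxy on the isopropyl compounds gives a 1.9-fold lower number from compound 3 to compound 4 (0.28 log units; within the scatter), so on this pair the change on the oxygen no longer clears the scatter, although it did on the cyclopropyl pair. Even so, the two results cannot be told apart, and the change may well be the same size on both: (the same change on two cores in this assay, a 4.1-fold lower number (0.61 log units; beyond the scatter) from compound 1 to compound 2 and a 1.9-fold lower number (0.28 log units; within the scatter) from compound 3 to compound 4, 2.1-fold (0.33 log units) apart, within the scatter of two such steps). The fourth compound also gives the first readable difference at the amide-type nitrogen, a 3.4-fold higher number from compound 2 to compound 4 (0.53 log units; beyond the scatter), yet this step too cannot be separated from the one measured on the hydroxy pair: (the same change on two cores in this assay, a 1.6-fold higher number (0.20 log units; within the scatter) from compound 1 to compound 3 and a 3.4-fold higher number (0.53 log units; beyond the scatter) from compound 2 to compound 4, 2.1-fold (0.33 log units) apart, within the scatter of two such steps).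

As far as these compounds go, with only these four compounds, it remains open how a longer chain such as propoxy, or an ethoxy carrying an amine at its end, would read on that oxygen. Also open, from the compounds shown here alone, is whether cyclobutyl or tert-butyl on the amide-type nitrogen would read closer to cyclopropyl or to isopropyl, and whether the gap between those two groups holds beyond the ethoxy pair.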